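The compounds below may be only part of what the source reports. "The series", "measured", "known", "first", "only" and "open" are said of these compounds alone.

Measured so far in a functional assay (mast cells) with Rattus norvegicus as the target; a higher number here means a weaker inhibitor, a lower number a stronger inhibitor:

- compound 1 `Cc1ccc2oc(-c3nnc(O)o3)nc2c1` (400 nM)
- compound 2 `O=C(/C=C/c1ccccc1)n1nc(-c2nc3ccccc3o2)oc1=O` (15000 nM)
- compound 3 `Cn1c(-c2nnc(O)o2)nc2ccccc21` (900 nM)

Compound 3 stands in the middle of these three numbers, with compound 1 lower and compound 2 higher, and both gaps lie beyond the scatter of repeated measurements. Still unmeasured is compound 4 `Cc1ccc2c(c1)nc(-c1nnc(O)o1)n2C`, which differs from compound 3 in one place (methyl in place of hydrogen on an aromatic carbon): methyl in place of hydrogen on an aromatic carbon of a six-membered aromatic ring of carbon only.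

Going by the values given here, no pair of measured compounds isolates this change, so the set offers no direct calibration for it. The only hint is weak: compound 1, at 400 nM, also carries a methyl on an aromatic carbon, but it differs from compound 3 in other ways as well. A modest move toward a lower number is therefore expected, not beyond the scatter, and a move in the opposite direction cannot be excluded. The estimated change is a 1.5-fold lower number from compound 3 to compound 4 (0.18 log units; within the scatter) in this assay, a small step. For compound 4 the estimated value is 600 nM, with an expected range from 200 nM to 1800 nM across repeat measurements.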

Compound 4, half-maximal inhibitory concentration: 6000 nM
Beside the measured number, compound 4's estimate is 10-fold (1.00 log units) below it; the whole stated range lies below it.
By their numbers in this assay, from the lowest: compound 1; then compound 3; then compound 4; then compound 2.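

In this assay, methyl in place of hydrogen on an aromatic carbon of the six-membered aromatic ring of carbon only, meta to a fused ring and para to a fused ring, gives a 6.7-fold higher number from compound 3 to compound 4 (0.82 log units; beyond the scatter) and so weakens inhibition beyond the scatter. Going by these compounds alone, this is the first pair that differs in one place, and it shows that this carbon is not a neutral site in this assay: a single added carbon atom, with no ring, no hydrogen-bond donor or acceptor and no net charge, is enough to produce a clear loss. No measured property of these compounds bears on this step, so the data give only its size and direction, not an explanation.

Open is whether the loss belongs to methyl itself or to any group at this carbon, since a fluorine, a methoxy group or a longer chain such as ethyl is not among the compounds shown. Within the data shown here, also open is whether a methyl on another carbon of the same six-membered ring would give a step of similar size or direction, as no such pair is available here.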